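A Dichlorophenyl Swap Near the Foot of the Scale

The source may hold more compounds than are shown below. What is called first, only, known or untested is meant among the compounds shown, and "the series" means these compounds.

In a functional assay on Caco-2 cells (Homo sapiens) for inhibition, read by MTT assay, with a stated time of 48 h, tested at 10 uM (on this read-out lower numbers stand for less inhibition of growth and higher numbers for more inhibition of growth at the one concentration tested), compound 1 `Cc1oc2c([C@H]3CCN(C)C[C@H]3O)c(O)cc(O)c2c(=O)c1C(O)c1csc([N+](=O)[O-])c1` gives 3% and compound 2 `COc1ccc(C(O)c2c(C)oc3c([C@H]4CCN(C)C[C@H]4O)c(O)cc(O)c3c2=O)cc1Br` gives 0% at the foot of the scale. Compound 2 therefore stands within the scatter of compound 1. Compound 3 `Cc1oc2c([C@H]3CCN(C)C[C@H]3O)c(O)cc(O)c2c(=O)c1C(O)c1cccc(Cl)c1Cl` keeps the shared core and carries 2,3-dichlorophenyl in place of 3-bromo-4-methoxyphenyl on a saturated chain carbon bound to an aromatic carbon and an oxygen on a saturated carbon. Among the measured compounds shown here, one measured step bears on this change, since it exchanges a different group at the same place: it is a number 3 percentage points lower from compound 1 to compound 2 (within the scatter) in this assay and no larger. One step is thin evidence, so the expected move is only a number 6 percentage points higher from compound 2 to compound 3 (within the scatter) with nothing beyond the scatter anticipated and no firm direction. For compound 3 the estimated value is 6% with an expected range from 0% to 22% on this scale.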

Compound 3, percent growth inhibition at one concentration: 3%
Beside the measured number, compound 3's estimate is 3 percentage points above it; the measured number falls inside the stated range.
By their numbers in this assay, from the lowest: compounds 2, 1 and 3 (each within the scatter of the next).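

In this assay putting 2,3-dichlorophenyl in place of 3-bromo-4-methoxyphenyl gives a number 3 percentage points higher from compound 2 to compound 3 (within the scatter) and putting it in place of 5-nitrothiophen-3-yl gives no change at the digits printed from compound 1 to compound 3 (within the scatter) on the same saturated chain carbon. Three different aromatic rings have now been read at this place, and no exchange among them moves the number beyond the scatter, whether the ring carries two chlorines, a bromine with a methoxy, or a nitro group. Nothing measured here explains why these three numbers sit so close together.

All three groups are aromatic rings, so an amine, a carboxylic acid or a longer alkyl chain at this place remains an open case. Also open, on these data alone, is whether any group on this carbon can give a number beyond the scatter of these three.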